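This account rests on a few compounds, and the source may have more. Where it says the series, first, only, none or still open, it means among the compounds named here.

Measured compounds:
Compound 1 `COc1ccc(-n2c(SCC(=O)c3ccc4ccccc4c3)nnc2-c2cc(OC)c(OC)c(OC)c2)cc1`: > 60000 nM
Compound 2 `COc1ccc(-n2c(SCC(=O)C3CC3)nnc2-c2cc(OC)c(OC)c(OC)c2)cc1`: > 60000 nM
Compound 3 `COc1cc(-c2nnc(SCC(=O)c3ccc4ccccc4c3)n2-c2ccc(N(C)C)cc2)cc(OC)c1OC`: > 60000 nM

In a functional assay on HepG2 cells (Homo sapiens) for inhibition, read by MTT assay, with a stated time of 48 h (a higher number here means a weaker inhibitor, a lower number a stronger inhibitor), compound 1 gives > 60000 nM, which is a limit of the assay and not a number. Compound 2 in this assay gives > 60000 nM, again only a limit. Compound 3 gives > 60000 nM, also a limit. The change from compound 1 to compound 2 is cyclopropyl in place of naphthalen-2-yl on a carbonyl carbon; its step that the two limits leave unreadable from compound 1 to compound 2 stays unreadable because of the limit of > 60000 nM in this assay, at which 3 of the 3 values shown sit. The two cores differ as dimethylamino in place of methoxy on an aromatic carbon, and the step that the two limits leave unreadable from compound 1 to compound 3 is unreadable for the same reason. Compound 4 `COc1cc(-c2nnc(SCC(=O)C3CC3)n2-c2ccc(N(C)C)cc2)cc(OC)c1OC` is not yet measured; it carries the same change as the first pair, (cyclopropyl in place of naphthalen-2-yl on a carbonyl carbon), at a place described in the same words. Given that three of three values sit at the limit, compound 4 is expected to give about 100000 nM, between 40000 nM and 300000 nM, a step that the limit leaves unreadable from compound 3 to compound 4, and most likely only a limit will be reported again.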

Compound 4, half-maximal inhibitory concentration: > 60000 nM
Compound 4: no number, only a limit; the forecaster's own chance of this, stated with the estimate: 85%; the middle value does not contradict the limit.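

Within the data shown here, no step to compound 4 can be read from compound 2 or compound 3, because each pair holds only limits: the limit of > 60000 nM in this assay, at which 4 of the 4 values shown sit. The compounds shown leave open how far, in this assay, either change, cyclopropyl for naphthalen-2-yl or dimethylamino for methoxy, shifts inhibition.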